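The source may hold more compounds than are shown below. What is called first, only, known or untested is meant among the compounds shown, and "the series" means these compounds.

Working notes on the series in a functional assay on the whole organism (Tail, strain ICR) with Mus musculus as the target, in the tail flick test, with a stated time of 90 min, at a dose of 25 umol/kg by the oral route; a higher number here means a stronger effect of the compound at the dose given, a lower number a weaker effect. Compound 1 `O=C(O)CC[C@H](NC(=O)CN(c1nc(Cl)nc2[nH]cnc12)C1CC1)C(=O)O` gives 44.7%. Compound 2 `CSCC[C@H](NC(=O)CN(c1nc(Cl)nc2[nH]cnc12)C1CC1)C(=O)O` gives 14%. Within the data shown here, the one single-point step measured so far, a number 30.7 percentage points lower from compound 1 to compound 2 (beyond the scatter), is large and downward. Compound 3 `NC(=O)C[C@H](NC(=O)CN(c1nc(Cl)nc2[nH]cnc12)C1CC1)C(=O)OCc1ccccc1` gives 32.3%, which places it second highest of the three numbers: below compound 1 and above compound 2, both gaps beyond the scatter.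

The next compound, compound 4 `NC(=O)C[C@H](NC(=O)CN(c1nc(Cl)nc2[nH]cnc12)C1CC1)C(=O)O`, differs from compound 3 by hydrogen in place of benzyl on an oxygen next to a carbonyl group. Among the measured compounds shown here, no measured step concerns this change; the only measured step touches a carboxy on the side chain, not the oxygen next to a carbonyl group on the main chain, so it does not bear directly on compound 4. Compounds 1 and 2 both carry the carboxy that enters here, and their values bracket compound 3 widely, which gives no clear direction. The expected step of a number 2.7 percentage points higher from compound 3 to compound 4 (within the scatter) is therefore small, not beyond the scatter. Compound 4 is estimated at 35%, with a range of 15% to 55%.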

Compound 4, a percentage reported as activity, at one dose (the size of the read-out at that dose, not a potency): 20.1%
Estimate against measurement, compound 4: 14.9 percentage points above; measured number inside the range.
By their numbers in this assay, from the lowest: compounds 2 and 4 (each within the scatter of the next); then compound 3; then compound 1.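

In this assay, among these compounds, hydrogen in place of benzyl on an oxygen next to a carbonyl group gives a number 12.2 percentage points lower from compound 3 to compound 4 (beyond the scatter), the first measured change at this place, so with the carbamoyl side chain held constant, benzyloxycarbonyl and carboxy are not interchangeable. Among the compounds with carboxy at this place, carbamoyl in place of (methylsulfanyl)methyl gives a number 6.1 percentage points higher from compound 2 to compound 4 (within the scatter), while carbamoyl in place of carboxymethyl gives a number 24.6 percentage points lower from compound 1 to compound 4 (beyond the scatter), so compound 1 stands apart from both compound 2 and compound 4. Nothing available explains the size or direction of these steps.

On these data alone, whether benzyl on this oxygen would give a similar step alongside the carboxymethyl side chain of compound 1 remains open. Also open, as far as these compounds go, is where a methyl ester or an ethyl ester at this oxygen would fall relative to compound 3 and compound 4.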